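Swapping 2-fluorophenyl for isopropyl on a potent urea

The compounds below may be only part of what the source reports. "The series", "measured", "known", "first", "only" and "open" are said of these compounds alone.

Compound 1 `CCOC(=O)c1cnn(CC(C)O)c1NC(=O)NCc1ccccc1`: 0.00054 nM
Compound 2 `CCOC(=O)c1cnn(CC(O)CC)c1NC(=O)NC(C)C`: 0.0042 nM
Compound 3 `CCOC(=O)c1cnn(CC(C)O)c1NC(=O)Nc1ccccc1F`: 0.00055 nM

These values come from a functional assay on cells (Neutrophil, Homo sapiens) for inhibition, with a stated time of 10 min; on this read-out lower numbers stand for stronger inhibition and higher numbers for weaker inhibition. Compound 3 sits level with compound 1, within the scatter, while compound 2 shows a higher number, beyond the scatter of compound 3.

Compound 4 `CCOC(=O)c1cnn(CC(C)O)c1NC(=O)NC(C)C` keeps the rest of compound 3 and carries isopropyl in place of 2-fluorophenyl on an amide-type nitrogen.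

Going by the values given here, only one measured step touches this nitrogen: a 1.0-fold higher number from compound 1 to compound 3 (0.01 log units; within the scatter). That step exchanges one ring-bearing group for another and changed nothing measurable, so it says little about losing the ring. The closer guide is compound 2 at 0.0042 nM, which also has isopropyl there but differs elsewhere as well. A move toward weaker inhibition is therefore expected, probably stopping short of the full gap to compound 2.

The expected change is a 3.6-fold higher number from compound 3 to compound 4 (0.56 log units; beyond the scatter). Compound 4 is estimated at 0.002 nM, with an expected range of 0.0005 nM to 0.008 nM.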

Compound 4, half-maximal inhibitory concentration: 0.00082 nM
For compound 4 the middle estimate is 2.4-fold (0.39 log units) above the measured one; the range from low to high includes it.
By their numbers in this assay, from the lowest: compounds 1, 3 and 4 (each within the scatter of the next); then compound 2.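

In this assay, the ring on this nitrogen proves dispensable: a 1.5-fold higher number from compound 3 to compound 4 (0.17 log units; within the scatter), and a 1.5-fold higher number from compound 1 to compound 4 (0.18 log units; within the scatter), so isopropyl stands level with both 2-fluorophenyl and benzyl. The step that does register lies on the saturated chain instead: a 5.1-fold lower number from compound 2 to compound 4 (0.71 log units; beyond the scatter), with hydrogen in place of methyl on a saturated chain carbon, two bonds along the chain from an oxygen on a saturated carbon, which places the gap to compound 2 at that chain and not at the nitrogen. Nothing at hand explains why either change has the size it does.

Still open, going by these compounds, is whether this nitrogen would accept a group of another kind, such as a carboxylic acid or a chain ending in an amine. Also open, on these data alone, is whether the chain step holds with 2-fluorophenyl or benzyl on the nitrogen, as it is read here only with isopropyl there.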